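Moving the nitrile on the benzyl ether of compound 3

The source may hold more compounds than are shown below. What is called first, only, known or untested is meant among the compounds shown, and "the series" means these compounds.

Measured so far:
compound 1 `CCN(C(=O)c1ccccc1OCc1ccccc1)C1CCNC1` — > 5000 nM
compound 2 `CCN(C(=O)c1ccccc1OCc1cccc(Cl)c1)C1CCCC(N)C1` — 96.6 nM
compound 3 `CCN(C(=O)c1ccccc1OCc1ccccc1C#N)C1CCCC(N)C1` — 1250 nM

The study turns on an assay on HEK293 cells for inhibition of transient receptor potential cation channel subfamily M member 8 (Homo sapiens), read by FLIPR and calcium flux; a higher number here means a weaker inhibitor, a lower number a stronger inhibitor. Compound 1 gives only the limit > 5000 nM there; it is a limit, not a number (the limit of > 5000 nM in this assay, at which 1 of the 3 values shown sits). Compound 2 reaches 96.6 nM, and compound 3 sits at 1250 nM, the highest of the two numbers that were obtained, separated from compound 2 by a step beyond the scatter (a 13-fold higher number from compound 2 to compound 3 (1.11 log units; beyond the scatter)).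

Compound 4 `CCN(C(=O)c1ccccc1OCc1ccc(C#N)cc1)C1CCCC(N)C1` is not yet measured. It differs from compound 3 in one place: 4-cyanophenyl in place of 2-cyanophenyl on a saturated chain carbon bound to an oxygen on an aromatic ring. Among the measured compounds shown here, only the step from compound 2 to compound 3 touches this position, and it was large. For the measured compounds named here, no measured pair shows a 4-cyanophenyl, so the direction is open. The writer expects compound 4 to move back toward the number of compound 2, with a moderate step of a 2.5-fold lower number from compound 3 to compound 4 (0.40 log units; beyond the scatter). Compound 4 is therefore estimated at 500 nM, within 150 nM to 2500 nM.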

Compound 4, antagonist equilibrium constant: 4590 nM
Compound 4: the middle estimate sits 9.2-fold (0.96 log units) below what was measured; the measured number lies above the stated range.
By their numbers in this assay, from the lowest: compound 2; then compound 3; then compound 4. At a limit, above all of these: compound 1.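

Replacing 2-cyanophenyl with 4-cyanophenyl, with the same atoms joined differently, gives a 3.7-fold higher number from compound 3 to compound 4 (0.56 log units; beyond the scatter) and so shows that the place of the nitrile on this ring still matters, and that moving it here does not regain what was lost with compound 3. Against the 3-chlorophenyl group of compound 2 the gap grows to a 48-fold higher number from compound 2 to compound 4 (1.68 log units; beyond the scatter) and leaves both nitrile-bearing groups well apart from the 3-chlorophenyl group on the saturated chain carbon bound to an oxygen on an aromatic ring. Nothing shown gives a reason for this order among the three groups.

The compounds shown leave open whether the gap to compound 2 follows the nitrile itself or the place of the substituent on the ring. A 3-cyanophenyl or a 4-chlorophenyl group on this same carbon would separate those two readings.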